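The source may report more compounds than this note shows. Statements on the series, on what has been measured and on what is new or still open speak of the compounds shown alone.

Working notes on the series. Compound 1 `Cc1ccc2nc(C(=O)Nc3c(F)cc(-c4cccc(F)c4)cc3F)c(C)c(C(=O)O)c2c1` in a functional assay on A-375 cells (Homo sapiens) for antiproliferative activity, read by MTT assay, with a stated time of 24 h, tested at 0.41 ug/mL (on this read-out lower numbers stand for a weaker effect and higher numbers for a stronger effect at the one concentration tested), gives 1.53%. Compound 2 `CCOc1ccc2nc(C(=O)Nc3c(F)cc(-c4cccc(F)c4)cc3F)c(C)c(C(=O)O)c2c1` in this assay gives 11.2%. The one change measured so far, ethoxy in place of methyl on an aromatic carbon, gives a number 9.7 percentage points higher from compound 1 to compound 2 (within the scatter); the two numbers lie within the scatter of each other, so compound 2 cannot be told apart from compound 1 on this read-out, and it stands nowhere beyond compound 1 on the numbers shown.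

Compound 3 `Cc1c(C(=O)Nc2c(F)cc(-c3cccc(F)c3)cc2F)nc2ccc(C(F)(F)F)cc2c1C(=O)O` is not yet measured. Relative to compound 2 it carries trifluoromethyl in place of ethoxy on an aromatic carbon The only measured step bears on this change solely in that it also alters the group at that aromatic carbon; it was a number 9.7 percentage points higher from compound 1 to compound 2 (within the scatter), and no measured pair sets ethoxy against trifluoromethyl. With one step in hand, and that one within the scatter, no step beyond the scatter is expected in this assay in either direction. The estimated step is a number 2.2 percentage points lower from compound 2 to compound 3 (within the scatter). Compound 3 is expected to give 9%, with a range from 0% to 26%.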

Compound 3, a percentage reported as inhibition, at one concentration (the size of the read-out at that concentration, not a potency): 7.82%
The estimate for compound 3 lay 1.2 percentage points above the measured number, and the stated range covers the measured number.
By their numbers in this assay, from the lowest: compounds 1, 3 and 2 (each within the scatter of the next).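

At this aromatic carbon, trifluoromethyl in place of ethoxy gives a number 3.4 percentage points lower from compound 2 to compound 3 (within the scatter) in this assay, and trifluoromethyl in place of methyl gives a number 6.3 percentage points higher from compound 1 to compound 3 (within the scatter), so all three groups cannot be told apart on this read-out. The earlier pair compared only methyl with ethoxy; this result adds a group that brings fluorine in place of carbon and oxygen and has no hydrogen-bond acceptor, where ethoxy has one, and even this change gives no step beyond the scatter. No measurement at hand accounts for this lack of separation among the three compounds.

The compounds shown leave open whether any group at this aromatic carbon can give a step beyond the scatter, for example an amine, a hydroxyl or a longer alkoxy chain such as butoxy. They also leave open whether the three groups would remain indistinguishable at other concentrations, since a single-concentration read-out gives the size of the effect at that concentration and not a potency.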